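The source may hold more compounds than are shown below. What is called first, only, known or untested is meant among the compounds shown, and "the series" means these compounds.

Compound 1 `CC(C)OC(=O)N1CCC(O[C@H]2CC[C@H](Oc3cnc(S(C)(=O)=O)cn3)CC2)CC1` carries a propan-2-yl group on the oxygen next to the carbonyl group, and in a functional assay on isolated protein for agonist activity at Glucose-dependent insulinotropic receptor (Rattus norvegicus), read by HTRF and cAMP accumulation (on this read-out higher numbers stand for an effect only at larger amounts of compound and lower numbers for an effect already at smaller amounts), compound 1 gives 119 nM. Among the measured compounds shown here, compound 2 `C[C@@H](CF)OC(=O)N1CCC(O[C@H]2CC[C@H](Oc3cnc(S(C)(=O)=O)cn3)CC2)CC1` gives 356 nM in this assay, the highest of the two numbers measured so far; the step of a 3.0-fold higher number from compound 1 to compound 2 (0.48 log units; beyond the scatter) lies beyond the scatter. Compound 3 `CS(=O)(=O)c1cnc(O[C@H]2CC[C@H](OC3CCN(C(=O)Oc4ccccc4)CC3)CC2)cn1` has not been measured. It differs from compound 2 in one place: phenyl in place of 1-(fluoromethyl)ethyl on an oxygen next to a carbonyl group. For the measured compounds named here, no measured step covers a phenyl group at this position; the only step known, from compound 1 to compound 2, concerns a fluorine on a saturated chain and does not bear directly on a change to an aromatic ring. Compound 3 is therefore expected to give about 250 nM in this assay, with a range from 60 nM to 1000 nM, a step of a 1.4-fold lower number from compound 2 to compound 3 (0.15 log units; within the scatter) that is expected to stay close to the scatter.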

Compound 3, half-maximal effective concentration: 71.8 nM
The estimate for compound 3 lay 3.5-fold (0.54 log units) above the measured number; low and high end bracket the measured number.
By their numbers in this assay, from the lowest: compounds 3 and 1 (each within the scatter of the next); then compound 2.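

Until now only saturated chains had been seen on the oxygen next to a carbonyl group, and compound 3 shows that a six-membered aromatic ring can sit there without loss in this assay: phenyl in place of 1-(fluoromethyl)ethyl gives a 5.0-fold lower number from compound 2 to compound 3 (0.70 log units; beyond the scatter) and phenyl in place of isopropyl gives a 1.7-fold lower number from compound 1 to compound 3 (0.22 log units; within the scatter) in the same read-out. The second step leaves phenyl and isopropyl indistinguishable here, so the chain and the ring serve equally well, while the fluorinated chain of compound 2 remains the outlier among the three. Nothing available explains either step.

Open, on these data alone, is whether this position accepts a phenyl ring bearing a chloro or methoxy group, or a pyridine ring. Also open, as far as these compounds go, is how a benzyl group or a longer chain would compare.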